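A phenyl group enters a series that sits at its limit

The compounds below may be only part of what the source reports. "The series", "measured", "known", "first", "only" and "open" are said of these compounds alone.

Compound 1, `CCc1nc(C)c2cnnc(S)n12`: in a functional assay for inhibition, with Homo sapiens as the target (a higher number here means a weaker inhibitor, a lower number a stronger inhibitor), compound 1 gives only a limit, > 48000 nM.
Compound 2, `CCc1nc(C)c2cnnc(SC)n12`: in this assay compound 2 gives only a limit, > 48000 nM.
Compound 3, `CCc1nc(C)c2cnnc(O)n12`: in this assay compound 3 gives only a limit, > 48000 nM.

All three measured compounds rest at the same limit, (the limit of > 48000 nM in this assay, at which 3 of the 3 values shown sit), so compound 2 has no place on a scale of numbers; its value is a limit and nothing more. The steps among the measured compounds, a step that the two limits leave unreadable from compound 1 to compound 2, a step that the two limits leave unreadable from compound 1 to compound 3 and a step that the two limits leave unreadable from compound 2 to compound 3, cannot be read in size or direction. Compound 4, `CCc1nc(C)c2c(-c3ccccc3)nnc(SC)n12`, differs from compound 2 by phenyl in place of hydrogen on an aromatic carbon. Within the data shown here, no measured step bears on this change, and nothing among the three compounds shows whether a phenyl group at this place moves the read-out of this assay at all. Compound 2 being a limit, any step from it stays unreadable until compound 4 is measured. With that caution, compound 4 is expected to give about 30000 nM in this assay, within 3000 nM to 100000 nM. The step this estimate implies, an at least 1.6-fold lower number from compound 2 to compound 4 (0.20 log units; that floor lies within the scatter), is an expectation only.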

Compound 4, half-maximal inhibitory concentration: > 48000 nM
Compound 4: no number, only a limit; the forecaster's own chance of this, stated with the estimate: 60%; middle value at least 1.6-fold (0.20 log units) from the limit.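

In this assay compound 4 gives > 48000 nM, which is a limit and not a number. Among these compounds, compound 2 is also only a limit, so no step between compound 2 and compound 4 can be read. The compounds shown leave open whether any change to the shared core would give a numerical value in this assay, as all of them rest at one limit: the limit of > 48000 nM in this assay, at which 4 of the 4 values shown sit.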